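Series notes: heteroaryl exchange on the double-bonded chain carbon

The compounds below may be only part of what the source reports. "The series", "measured", "known", "first", "only" and "open" are said of these compounds alone.

Measured so far in an assay on isolated protein for inhibition of Amine oxidase [flavin-containing] A (Homo sapiens), read by fluorescence; a higher number here means a weaker inhibitor, a lower number a stronger inhibitor:
compound 1 `O=C(/C=C/c1cccs1)c1cc(O)c(O)c([N+](=O)[O-])c1` gives 49900 nM
compound 2 `O=C(/C=C/c1ccco1)c1cc(O)c(O)c([N+](=O)[O-])c1` gives 60500 nM
compound 3 `CC(=O)N1N=C(c2cc(O)c(O)c([N+](=O)[O-])c2)CC1c1cccc(O)c1` gives 87000 nM

Compound 2 stands second highest of the three numbers; compound 1 sits nearest to it and compound 3 furthest, both within the scatter, so no order among the three can be drawn. Compound 4 `Cn1cc(/C=C/C(=O)c2cc(O)c(O)c([N+](=O)[O-])c2)cn1` is not yet measured. It differs from compound 2 as follows: 1-methyl-1H-pyrazol-4-yl in place of furan-2-yl on a double-bonded chain carbon bound to a double-bonded chain carbon. Among the measured compounds shown here, the one measured step that bears on this change is the exchange of one five-membered heteroaryl for another at the same place, a 1.2-fold higher number from compound 1 to compound 2 (0.08 log units; within the scatter), which stayed within the scatter. A second heteroaryl exchange at the same place is therefore expected to move the number in this assay by no more than the scatter, with no direction preferred. The estimate for compound 4 is 60000 nM, within 25000 nM to 150000 nM, meaning an expected step of a 1.0-fold lower number from compound 2 to compound 4 (0.00 log units; within the scatter). For the measured compounds named here, the range is kept wide, as only one prior step of this kind is in hand and compound 3 carries a different change altogether.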

Compound 4, half-maximal inhibitory concentration: 51500 nM
Estimate against measurement, compound 4: 1.2-fold (0.07 log units) above; the measured number falls inside the stated range.
By their numbers in this assay, from the lowest: compounds 1, 4, 2 and 3 (each within the scatter of the next).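

In this assay the step to the third five-membered aromatic ring at this place is a 1.2-fold lower number from compound 2 to compound 4 (0.07 log units; within the scatter) and, against the other heteroaryl, a 1.0-fold higher number from compound 1 to compound 4 (0.01 log units; within the scatter) as well. The exchange therefore holds within the scatter even when 1-methyl-1H-pyrazol-4-yl brings one more heavy atom, a second ring hetero atom and a second hydrogen-bond acceptor, which the earlier step between two rings with one hetero atom each could not show. No measurement in hand offers an explanation for this result.

From the compounds shown here alone, no change at this place yet moves the number beyond the scatter, so it remains open whether the position responds at all. A phenyl ring, a ring carrying an amine or a carboxylic acid, or a longer chain on the 1-methyl-1H-pyrazol-4-yl nitrogen would test that.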